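The compounds below may be only part of what the source reports. "The series", "measured", "known", "first", "only" and "open" are said of these compounds alone.

Measured so far in an assay on CHO cells for displacement of a labelled ligand from adenosine receptor A3 (Homo sapiens); a higher number here means a weaker inhibitor, a lower number a stronger inhibitor:
compound 1 `COc1ccc(NC(=O)Nc2nc(-c3ccccc3)nc3nn(C)cc23)cc1` gives 358 nM
compound 2 `COc1ccc(C(=O)Nc2ncnc3nn(Cc4ccccc4)cc23)cc1` gives > 1000 nM

Compound 1 carries a urea and a methyl on its core and is the one of the two with a numerical result. For compound 2 the result in this assay is only a limit, > 1000 nM, so it is not known how far beyond that boundary the true value lies; this is the limit of > 1000 nM in this assay, at which 1 of the 2 values shown sits. Within the data shown here, the two compounds differ in several places at once, so no single step between them can be read from their values.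

Compound 3 `O=C(Nc1ncnc2nn(Cc3ccccc3)cc12)c1cccc(Cl)c1` keeps the benzyl-bearing core and the amide of compound 2 and changes only the aryl on the carbonyl: 3-chlorophenyl in place of 4-methoxyphenyl on a carbonyl carbon. Since compound 2 gave no number, the step from it to compound 3 can only be sketched. A large shift from a limit seems unlikely; the estimated step that the limit leaves unreadable from compound 2 to compound 3 is expected to stay near the scatter, in either direction. Compound 3 is therefore estimated at 2000 nM in this assay, with a range from 500 nM to 10000 nM, and a fair chance that once more only a limit is reported.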

Compound 3, inhibition constant: > 1000 nM
Compound 3 gave a limit, no number (the forecaster's own chance of this, stated with the estimate: 60%); the middle value lies beyond the limit too.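

In this assay compound 2 and compound 3 both give only a limit, so no step between them can be read, and the change to 3-chlorophenyl in place of 4-methoxyphenyl on a carbonyl carbon stays without a size: the limit of > 1000 nM in this assay, at which 2 of the 3 values shown sit.

In this assay the compounds shown leave open how far beyond that limit compound 2 and compound 3 lie, and whether the aryl on the carbonyl changes the result at all.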